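This account rests on a few compounds, and the source may have more. Where it says the series, first, only, none or still open, it means among the compounds named here.

Measured in an ADME assay on RAW264.7 cells (Mus musculus) for cytotoxicity, read by MTT assay; a lower number here means a stronger inhibitor, a higher number a weaker inhibitor:
Compound 1 `CC(C)CCOc1cccc(O)c1C(=O)/C=C/c1ccc(O)cc1`: > 30000 nM
Compound 2 `CCCCCCCCCCCCCCCCOc1cccc(O)c1C(=O)/C=C/c1ccc(O)cc1`: > 30000 nM
Compound 3 `CCCCCCCCCCOc1cccc(O)c1C(=O)/C=C/c1cccc(O)c1`: > 30000 nM

All three compounds stand at the limit of > 30000 nM in this assay, at which 3 of the 3 values shown sit. Compound 3 gives > 30000 nM, which is a limit and not a number. Among the measured compounds shown here, no step between measured compounds is available.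

Compound 4 `CCCCCCCCCCOc1cccc(O)c1C(=O)/C=C/c1ccc(Cl)c(Cl)c1` carries 3,4-dichlorophenyl in place of 3-hydroxyphenyl on a double-bonded chain carbon bound to a double-bonded chain carbon. In this assay, only a modest move towards a lower number is expected, and another limit may well be reported. The estimated step of an at least 1.2-fold lower number from compound 3 to compound 4 (0.07 log units; that floor lies within the scatter) is expected to be small. Compound 4 is estimated at 25000 nM, with an expected range of 8000 nM to 50000 nM.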

Compound 4, half-maximal inhibitory concentration: > 30000 nM
Compound 4: no number, only a limit; the forecaster's own chance of this, stated with the estimate: 55%; middle value at least 1.2-fold (0.07 log units) from the limit.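

Among the compounds shown here, compound 3 and compound 4 both stand at a limit, so no step between them can be read in this assay: the limit of > 30000 nM in this assay, at which 4 of the 4 values shown sit. The compounds shown leave open whether any change to the shared core would give a readable number in this assay at all.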